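A Bromine for an Iodine on the Selenium Core

The source may report more compounds than this note shows. Statements on the series, on what has been measured and on what is new or still open speak of the compounds shown alone.

Two measured compounds set the scene. Compound 1 `Ic1nc2ccccc2[se]1` carries an iodo group on its core. In a functional assay on NCI-H522 cells (Homo sapiens) for cytotoxicity, with a stated time of 3 days (on this read-out lower numbers stand for stronger inhibition and higher numbers for weaker inhibition), compound 1 gives only a limit, > 40000 nM. Compound 2 `C#Cc1nc(-c2ccccc2)cs1` is built on a different core, and in this assay compound 2 gives 5650 nM. Among the measured compounds shown here, no step between measured compounds that differ in a single place is available, so the picture rests on the limit of > 40000 nM in this assay, at which 1 of the 2 values shown sits, alone. The unmeasured compound 3 `Brc1nc2ccccc2[se]1` differs from compound 1 in one place: bromo in place of iodo on an aromatic carbon. For an exchange of one halogen for another, the expectation is no step beyond the scatter from compound 1, the estimated change being a number no higher from compound 1 to compound 3 (the limit leaves the size open). Compound 3 is therefore expected at about 40000 nM, with a likely range from 15000 nM to 100000 nM, and most probably it too will return only a limit.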

Compound 3, half-maximal inhibitory concentration: > 40000 nM
Compound 3: a limit, no number; the forecaster's own chance of this, stated with the estimate: 75%; the middle value sits exactly at the limit.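

Among the compounds shown here, compound 1 and compound 3 each return only a limit in this assay, so no step from iodo to bromo can be read between them. The compounds shown leave open where the true values of both lie, and the results gather at one point: the limit of > 40000 nM in this assay, at which 2 of the 3 values shown sit.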